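Swapping a nitrogen-bearing bicycle for cyclopentyl on a chain

The source may report more compounds than this note shows. Statements on the series, on what has been measured and on what is new or still open speak of the compounds shown alone.

Of the compounds shown here, two sharing one core have been measured in a functional assay on CHO cells for inhibition of Gonadotropin-releasing hormone receptor (Homo sapiens); a higher number here means a weaker inhibitor, a lower number a stronger inhibitor. Compound 1 `Cc1cc(-c2c(O)nc3cc(Cl)c(C(=O)Nc4cnsn4)cc3c2OCCC2CC3CCN2CC3)cc(C)c1C` gives 5.8 nM. Compound 2 `Cc1cc(-c2c(O)nc3cc(Cl)c(C(=O)Nc4ccncn4)cc3c2OCC[C@@H]2CCCN2)cc(C)c1C` gives 2.2 nM. Among the compounds with values here, compound 1 thus has the higher of the two numbers, and the gap to compound 2 lies beyond the scatter; the two differ in more than one place, so no single step connects them.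

Compound 3 `Cc1cc(-c2c(O)nc3cc(Cl)c(C(=O)Nc4cnsn4)cc3c2OCCC2CCCC2)cc(C)c1C` is not yet measured. It arises from compound 1 by the change (a group of 5 heavy atoms (5 carbon; one five-membered non-aromatic ring of carbon only) in place of a group of 8 heavy atoms (7 carbon, 1 nitrogen; 2 six-membered non-aromatic rings with 1 hetero atom each), on a saturated chain carbon, two bonds along the chain from an oxygen on an aromatic ring). Within the data shown here, both measured compounds carry a ring that holds a nitrogen on that chain; compound 3 would be the first without one, so no measured step in this set covers such a change.

The expectation is a loss of potency for compound 3, as a step of a 17-fold higher number from compound 1 to compound 3 (1.24 log units; beyond the scatter) in this assay. The estimate for compound 3 is 100 nM, with a range from 20 nM to 600 nM, a wide span since nothing measured here anchors it.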

Compound 3, half-maximal inhibitory concentration: 1150 nM
Estimate against measurement, compound 3: 12-fold (1.06 log units) below; measured number above the stated range.
By their numbers in this assay, from the lowest: compound 2; then compound 1; then compound 3.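

Putting cyclopentyl in place of the nitrogen-bearing bicycle on this chain gives, in this assay, a 200-fold higher number from compound 1 to compound 3 (2.30 log units; beyond the scatter), and this is a large step. The group at this place is therefore far from interchangeable: inhibition of the receptor depends strongly on what sits on the saturated chain carbon, two bonds along the chain from an oxygen on an aromatic ring. Nothing measured on these compounds beyond the inhibition numbers themselves explains this step.

The step changes several things at once: the group that leaves has 8 heavy atoms, two rings, a nitrogen and 1 hydrogen-bond acceptor, while cyclopentyl has 5 heavy atoms, one ring, no nitrogen and 0 hydrogen-bond acceptors, so the compounds shown cannot say which of these differences carries the loss. A dimethylamino group on the same chain would keep a nitrogen without a ring, and a cyclohexyl group would keep a carbon-only ring with more heavy atoms than cyclopentyl, so these two groups could begin to pull those differences apart.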